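The source may report more compounds than this note shows. Statements on the series, on what has been measured and on what is new or still open speak of the compounds shown alone.

Compound 1 `CS(=O)(=O)c1ccc(Nc2nccc(Nc3nc4ccc(F)cc4s3)n2)cc1` gives 2080 nM in a functional assay on MDA-MB-231 cells (Homo sapiens) for antiproliferative activity, read by MTT assay, with a stated time of 48 h; on this read-out lower numbers stand for stronger inhibition and higher numbers for weaker inhibition.
Compound 2 `Cc1cnc(Nc2ccc(S(N)(=O)=O)cc2)nc1Nc1nc2ccccc2s1` gives 16800 nM in this assay.

Of these two numbers, compound 1 has the lower one; the number of compound 2 stands higher by a gap beyond the usual scatter. Compound 3 `CS(=O)(=O)c1ccc(Nc2ncc(F)c(Nc3nc4ccc(F)cc4s3)n2)cc1` differs from compound 1 by fluoro in place of hydrogen on an aromatic carbon. Going by the values given here, no single step between measured compounds is available to set the size of such a change, so the expectation rests on the scale of the numbers seen. A small step toward a lower number is expected, a 1.6-fold lower number from compound 1 to compound 3 (0.20 log units; within the scatter), one that may well stay within the scatter. Compound 3 is estimated at 1300 nM, with a range from 350 nM to 5000 nM.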

Compound 3, half-maximal inhibitory concentration: 8900 nM
Beside the measured number, compound 3's estimate is 6.8-fold (0.84 log units) below it, outside the stated range (above it).
By their numbers in this assay, from the lowest: compound 1; then compounds 3 and 2 (each within the scatter of the next).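

In this assay, fluoro in place of hydrogen on this aromatic carbon, ortho to a large group and two atoms from the ring nitrogen, is not a neutral change: it gives a 4.3-fold higher number from compound 1 to compound 3 (0.63 log units; beyond the scatter). Going by these compounds alone, this is the first single-place step available here, and it runs toward weaker inhibition, so this position responds to even one added heavy atom. No available evidence bears on the reason for this step. Going by these compounds, whether methyl, chloro or an amine on this carbon would move the number in the same direction, or by a similar amount, remains open.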